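The source may report more compounds than this note shows. Statements on the series, on what has been measured and on what is new or still open speak of the compounds shown alone.

Compound 1, `COc1cccc(NC(=O)COc2cc(C)nc3ccc(OC)cc23)c1`: in a toxicity assay on HepG2 cells (Homo sapiens) for inhibition, read by CellTiter-Glo, with a stated time of 48 h (a lower number here means a stronger inhibitor, a higher number a weaker inhibitor), compound 1 gives > 100000 nM, which is a limit of the assay and not a number.
Compound 2, `COc1ccc(NC(=O)COc2cc(C)nc3ccc(OC)cc23)cc1`: in this assay compound 2 gives > 100000 nM, again a limit.
Compound 3, `COc1ccc2nc(C)cc(OCC(=O)Nc3ccc(Cl)cc3Cl)c2c1`: in this assay compound 3 gives > 100000 nM, once more a limit.

All three compounds share one core and differ only in the ring that sits on the amide-type nitrogen. For the measured compounds named here, compound 3 therefore stands exactly where the other two stand, at the limit described by the limit of > 100000 nM in this assay, at which 3 of the 3 values shown sit; no measured compound in this set has a readable number.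

Compound 4, `COc1ccc2nc(C)cc(OCC(=O)Nc3ccc(F)cc3)c2c1`, is the next compound to be tested. It differs from compound 3 by 4-fluorophenyl in place of 2,4-dichlorophenyl on an amide-type nitrogen. The measured steps that touch the same position are a step that the two limits leave unreadable from compound 1 to compound 3, a step that the two limits leave unreadable from compound 2 to compound 3 and a step that the two limits leave unreadable from compound 1 to compound 2. Each of these joins two limits, so none of them gives a size or a direction. Going by the values given here, they show only that three different rings on that nitrogen all left the value beyond the reach of the assay.

On that basis compound 4 is expected to behave in the same way, with no step beyond the scatter foreseen, as the estimated step that the limit leaves unreadable from compound 3 to compound 4 expresses. The estimate for compound 4 in this assay is 150000 nM, with a range from 40000 nM to 600000 nM.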

Compound 4, half-maximal inhibitory concentration: 63100 nM
Compound 4: middle estimate off by 2.4-fold (0.38 log units), on the high side; the range from low to high includes it.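

In this assay compound 4 gives 63100 nM, the only readable number among the compounds shown, so a ring on the amide-type nitrogen can bring the value within reach of the assay, and the change from 2,4-dichlorophenyl to 4-fluorophenyl reads as an at least 1.5-fold lower number from compound 3 to compound 4 (0.19 log units; that floor lies within the scatter). The comparisons with the two methoxy compounds read the same way, as an at least 1.5-fold lower number from compound 2 to compound 4 (0.19 log units; that floor lies within the scatter) and as an at least 1.5-fold lower number from compound 1 to compound 4 (0.19 log units; that floor lies within the scatter); each is only a floor, so the true size of these steps stays unknown and none is shown to lie beyond the scatter. Compound 4 is thus the first sign that this position may affect the value, but the other compounds give no number to measure it against: the limit of > 100000 nM in this assay, at which 3 of the 4 values shown sit.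

With a single readable value, the compounds shown cannot rank the rings on this nitrogen or show whether any of them differs from compound 4 by more than the scatter. They also leave open what a 4-chlorophenyl, an amine, a carboxylic acid or a longer chain in place of the 4-fluorophenyl would do to the value.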